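Bromo to chloro exchange on compound 3

A few compounds are considered here, and "the series" means these few. Any claim that something is new, unique, unknown or untested is made for them only; others in the source may bear on it.

Measured so far in an ADME assay on A549 cells (Homo sapiens) for inhibition, read by MTT assay; a higher number here means a weaker inhibitor of growth, a lower number a stronger inhibitor of growth:
compound 1 `Cc1ccc(O)c(C(=O)/C=C/c2cn(-c3ccc(F)cc3)nc2-c2sc(C)nc2C)c1`, 47.8 ug/mL
compound 2 `Cc1nc(C)c(-c2nn(-c3ccc(F)cc3)cc2/C=C/C(=O)c2c(O)cc(C)c(Cl)c2C)s1`, 33.5 ug/mL
compound 3 `Cc1nc(C)c(-c2nn(-c3ccc(F)cc3)cc2C2CC(c3cc(Br)ccc3O)=NN2)s1`, 81.4 ug/mL

Compound 3 holds the highest number of the three; its gap to compound 1 is within the scatter, its gap to compound 2 beyond it. Compound 4 `Cc1nc(C)c(-c2nn(-c3ccc(F)cc3)cc2C2CC(c3cc(Cl)ccc3O)=NN2)s1` differs from compound 3 by chloro in place of bromo on an aromatic carbon. Among the measured compounds shown here, the single measured step, a 1.4-fold lower number from compound 1 to compound 2 (0.15 log units; within the scatter), alters the aryl group on the carbonyl carbon and does not involve this position, so no measured pair speaks directly to a bromo-for-chloro exchange. Without such an anchor, compound 4 is expected to stay close to compound 3, a step of a 1.1-fold lower number from compound 3 to compound 4 (0.04 log units; within the scatter) that is not expected to exceed the scatter. The estimate for compound 4 is 75 ug/mL, with a range from 38 ug/mL to 150 ug/mL.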

Compound 4, concentration for 50% growth inhibition: > 250 ug/mL
Compound 4: a limit, no number; the forecaster's own chance of this, stated with the estimate: 10%; middle value at least 3.3-fold (0.52 log units) away from the limit.
By their numbers in this assay, from the lowest: compounds 2, 1 and 3 (each within the scatter of the next, the first and the last beyond it). At a limit, above all of these: compound 4.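

Chloro in place of bromo on this aromatic carbon, para to the hydroxy group, is not a neutral exchange in this assay: it gives an at least 3.0-fold higher number from compound 3 to compound 4 (0.48 log units; beyond the scatter). Among the compounds shown here, no earlier pair touched this position, so this is the first sign that the number responds to the halogen here. The value of compound 4 is a limit and not a number, so the step gives only a minimum for the change: the limit of > 250 ug/mL in this assay, at which 1 of the 4 values shown sits.

Going by these compounds, it remains open how far the number rises for compound 4. On these data alone, it is also open whether fluoro, methoxy or an amine at this carbon would stay near compound 3 or also reach the limit.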